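A few compounds are considered here, and "the series" means these few. Any claim that something is new, unique, unknown or untested is made for them only; others in the source may bear on it.

Compound 1 `O[C@]1(c2ccccn2)CC[C@H](c2ccc(C(F)(F)F)cc2)C1` was tested in an assay on HEK293 cells for antagonist activity at transient receptor potential cation channel subfamily V member 3 (Homo sapiens), read by FLIPR and calcium flux (on this read-out higher numbers stand for weaker inhibition and lower numbers for stronger inhibition), where compound 1 gives 540 nM. Among the two numbers available this is the higher one, so compound 1 is the weaker inhibitor of that pair. Compound 2 `O[C@H](c1ccccn1)[C@]1(c2cccc(C(F)(F)F)c2)C[C@H](O)C1`, a relative with a different arrangement of the same kinds of pieces, gives 90 nM in this assay, a gap that lies beyond the usual scatter of repeated measurements. For compound 3 `C[C@]1(O)C[C@](c2cc(C(F)(F)F)ccn2)([C@@H](O)c2ccccn2)C1`, this assay reports only a limit, > 9100 nM, and not a measured number (the limit of > 9100 nM in this assay, at which 1 of the 3 values shown sits).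

Going by the values given here, compound 4 `O[C@@]1(c2ccccn2)CC[C@H](c2ccc(C(F)(F)F)cc2)C1` has not yet been measured. the two compounds have the same atoms and bonds and differ only in configuration as drawn: 1 of 2 stereo elements differ; a stereocentre at a saturated ring carbon is drawn R in compound 1 and S in compound 4 No measured pair in this set shows what flipping such a ring centre does, so neither the direction nor the size of the step can be read from the data, and any guess has to carry a wide range. Compound 4 is therefore estimated at 1100 nM in this assay, somewhere between 250 nM and 6000 nM, which corresponds to an expected step of a 2.0-fold higher number from compound 1 to compound 4 (0.31 log units; beyond the scatter).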

Compound 4, antagonist equilibrium constant: 610 nM
Estimate against measurement, compound 4: 1.8-fold (0.26 log units) above; measured number inside the range.
By their numbers in this assay, from the lowest: compound 2; then compounds 1 and 4 (each within the scatter of the next). At a limit, above all of these: compound 3.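

Going by these compounds alone, this is the first pair in the set where only one thing changes, so the step can be read directly: the fact that compounds 1 and 4 differ only in the configuration as drawn. Turning this saturated ring carbon from R to S gives a 1.1-fold higher number from compound 1 to compound 4 (0.05 log units; within the scatter) in this assay. At this one centre, on this core, the configuration as drawn therefore makes no difference that the assay can separate from the scatter of repeated measurements, so neither form stands apart from the other.

As far as these compounds go, the second stereocentre is drawn the same way in compound 1 and compound 4, so the effect of turning that centre, or of turning both together, remains open. Also open, from the compounds shown here alone, is whether the two forms would stay this close if the hydroxyl were replaced by an amine or a carboxylic acid.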